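Methoxy substitution carried from one core to another

The source may hold more compounds than are shown below. What is called first, only, known or untested is meant among the compounds shown, and "the series" means these compounds.

Compound 1 `CC[C@@H](CCn1cncn1)c1ccccc1` is the parent of this small set. In an ADME assay on HEp-2 cells (Homo sapiens) for cytotoxicity, read by MTT assay, with a stated time of 3 days (on this read-out higher numbers stand for lower toxicity in this test and lower numbers for higher toxicity in this test), compound 1 gives 89.9 ug/mL. Compound 2 `CC[C@@H](CCn1cncn1)c1ccc(OC)cc1` carries the change (methoxy in place of hydrogen on an aromatic carbon). In this assay compound 2 gives 146 ug/mL, and the step is a 1.6-fold higher number from compound 1 to compound 2 (0.21 log units; within the scatter). Compound 3 `c1ccc(C[C@@H](CCn2cncn2)c2ccccc2)cc1` rests on a different core, which differs from that of compound 1 by phenyl in place of methyl on a saturated chain carbon, two bonds along the chain from an aromatic carbon. In this assay compound 3 gives 55.9 ug/mL, and the step is a 1.6-fold lower number from compound 1 to compound 3 (0.21 log units; within the scatter). Compound 3 holds the lowest number of the three, but its gap to compound 1 is within the scatter, so no order between those two is claimed; only compound 2 stands beyond the scatter from compound 3.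

Compound 4 `COc1ccc([C@H](CCn2cncn2)Cc2ccccc2)cc1` is not yet measured. It differs from compound 3 by methoxy in place of hydrogen on an aromatic carbon. This is the same change that turns compound 1 into compound 2: the place of the change is described in identical words for both pairs, and it appears twice among the four compounds. Within the data shown here, the expectation for compound 4 rests on the single measured instance of this change, a 1.6-fold higher number from compound 1 to compound 2 (0.21 log units; within the scatter), which was within the scatter. Compound 4 is therefore expected to come out near 85 ug/mL, with a likely range from 45 ug/mL to 160 ug/mL. The step this estimate implies, a 1.5-fold higher number from compound 3 to compound 4 (0.18 log units; within the scatter), is expected to be small and within the usual scatter. One prior instance on a different core gives no basis for a larger move in either direction, and a reported limit instead of a number is judged unlikely.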

Compound 4, half-maximal cytotoxic concentration: 60.3 ug/mL
Compound 4: the middle estimate sits 1.4-fold (0.15 log units) above what was measured, within the range that was stated.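

On the core of compound 3, methoxy in place of hydrogen on an aromatic carbon gives a 1.1-fold higher number from compound 3 to compound 4 (0.03 log units; within the scatter) in this assay, and the two instances of this change do not differ by more than can be expected between two such steps: the same change on two cores in this assay, a 1.6-fold higher number (0.21 log units; within the scatter) from compound 1 to compound 2 and a 1.1-fold higher number (0.03 log units; within the scatter) from compound 3 to compound 4, 1.5-fold (0.18 log units) apart, within the scatter of two such steps

Read along the other edge of the set, phenyl in place of methyl on a saturated chain carbon gives a 2.4-fold lower number from compound 2 to compound 4 (0.38 log units; beyond the scatter), a modest step that lies beyond the scatter while its counterpart on the core of compound 1 lies within it, yet the gap between the two steps is still within the scatter: the same change on two cores in this assay, a 1.6-fold lower number (0.21 log units; within the scatter) from compound 1 to compound 3 and a 2.4-fold lower number (0.38 log units; beyond the scatter) from compound 2 to compound 4, 1.5-fold (0.18 log units) apart, within the scatter of two such steps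

Both changes therefore carry from one core to the other without a detectable difference in this read-out, but two pairs in a set of four compounds do not show that the steps are equal, and they do not show that the same would hold on any further core.

On these data alone, whether another group at the same place on the aromatic ring, such as an amine, a carboxylic acid or trifluoromethyl, would carry across the two cores in the same way stays open. So does the outcome of a longer chain in place of the methyl or the phenyl on the saturated chain carbon.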